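Swapping Ring Stereochemistry on a Shared Core

The compounds below may be only part of what the source reports. "The series", "measured", "known", "first", "only" and "open" are said of these compounds alone.

Measured so far:
compound 1, `CNC(=O)Nc1ccc(-c2nc(N3CC4CCC(C3)O4)c3cnn([C@H]4CC[C@@H](OC)CC4)c3n2)cc1`: 1 nM
compound 2, `O=C(Nc1ccccc1)Nc1ccc(-c2nc(N3CC4CCC(C3)O4)c3cnn(C4CCC5(CC4)OCCO5)c3n2)cc1`: 4 nM

Of the compounds shown here, two sharing the same core have been measured in a functional assay on LNCaP cells (Homo sapiens) for cytotoxicity; a higher number here means a weaker inhibitor, a lower number a stronger inhibitor. Compound 1 gives 1 nM, the lower of the two numbers, and compound 2 gives 4 nM, a higher number that lies beyond the usual scatter of repeated measurements. Compound 1 therefore stands at the strong end of what has been measured.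

Compound 3, `CNC(=O)Nc1ccc(-c2nc(N3CC4CCC(C3)O4)c3cnn([C@H]4CC[C@H](OC)CC4)c3n2)cc1`, has not yet been tested in this assay. It differs from compound 1 in this way: the two compounds have the same atoms and bonds; at least one stereo element is drawn with a configuration in one of them and without one in the other: 2 of 4 stereo elements differ; a stereocentre at a saturated ring carbon is drawn s in compound 1 and r in compound 3; a stereocentre at a saturated ring carbon is drawn s in compound 1 and r in compound 3. The two compounds have the same atoms and bonds; only two of four stereo elements differ, each a stereocentre at a saturated ring carbon drawn s in compound 1 and r in compound 3.

Going by the values given here, no measured pair shows what such a change does here, so the expectation rests on compound 1 alone. A small loss is expected rather than a gain, with a fair chance that the step stays within the scatter. The expected step of a 2.0-fold higher number from compound 1 to compound 3 (0.30 log units; within the scatter) is therefore modest. Compound 3 is estimated to give 2 nM in this assay, with a likely range from 0.5 nM to 8 nM.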

Compound 3, half-maximal inhibitory concentration: 2 nM
Compound 3: middle estimate and measured number agree at the digits printed; the measured number falls inside the stated range.
By their numbers in this assay, from the lowest: compounds 1, 3 and 2 (each within the scatter of the next, the first and the last beyond it).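

In this assay, the only difference between the two compounds is the drawn configuration at two stereocentres at saturated ring carbons, and it gives a 2.0-fold higher number from compound 1 to compound 3 (0.30 log units; within the scatter). Going by these compounds alone, this is the first comparison confined to a single kind of difference, with the atoms and bonds the same, and the two numbers cannot be told apart beyond ordinary repeat variation, so neither configuration can be ranked above the other in this cell assay. The reading of this pair carries one qualification, which concerns how the two structures are drawn: the fact that one of compounds 1 and 3 is drawn with a defined configuration and the other without, at the place where they differ

What the compounds shown leave open is whether this insensitivity to configuration holds only for the methoxy compounds or also when another group, such as an amine or a carboxylic acid, takes the place of methoxy on the same ring. They also leave open whether the same pair of configurations would give equally close numbers with a larger urea substituent, such as the phenyl urea of compound 2, in place of the methyl urea of compound 1 and compound 3.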